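This account rests on a few compounds, and the source may have more. Where it says the series, first, only, none or still open, it means among the compounds named here.

Of the two compounds with a measured value, compound 2 `CCC(CC)[C@@H]1C(=O)N[C@H](C2Cc3ccccc3C2)C(=O)N1[C@@H](C(=O)N(C)C)c1ccc(C)nc1` shows the lower number: in an assay on isolated protein for displacement of a labelled ligand from Oxytocin receptor (Homo sapiens) (a higher number here means a weaker inhibitor, a lower number a stronger inhibitor), compound 2 gives 0.0501 nM, while compound 1 `Cc1ccc([C@H](C(=O)N(C)C)N2C(=O)[C@@H](C3Cc4ccccc4C3)NC(=O)[C@H]2CC(C)C)cn1` gives 1.59 nM. Going by the values given here, the only measured step at this position, a 32-fold lower number from compound 1 to compound 2 (1.50 log units; beyond the scatter), came from swapping isobutyl for pentan-3-yl. Compound 3 `Cc1ccc([C@H](C(=O)N(C)C)N2C(=O)[C@@H](C3Cc4ccccc4C3)NC(=O)[C@H]2CC(C)(C)C)cn1` differs from compound 2 by neopentyl in place of pentan-3-yl on a saturated ring carbon. With the same number of carbons but a branching pattern more like isobutyl, compound 3 is expected to give a weaker result than compound 2, a step of about a 10-fold higher number from compound 2 to compound 3 (1.00 log units; beyond the scatter), so that compound 3 is estimated at 0.5 nM (range 0.1 nM to 3 nM).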

Compound 3, inhibition constant: 0.0631 nM
Compound 3: the middle estimate sits 7.9-fold (0.90 log units) above what was measured; measured number outside the range, below it.
By their numbers in this assay, from the lowest: compounds 2 and 3 (each within the scatter of the next); then compound 1.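

Swapping pentan-3-yl for neopentyl at this saturated ring carbon leaves binding in this assay unchanged within the scatter (a 1.3-fold higher number from compound 2 to compound 3 (0.10 log units; within the scatter)), even though the two groups have the same atoms joined differently. A methyl in place of hydrogen on the isobutyl group of compound 1 has a large effect (a 25-fold lower number from compound 1 to compound 3 (1.40 log units; beyond the scatter)), so both five-carbon groups give a similar advantage over isobutyl. No evidence is available to explain this advantage. The compounds shown leave open how a cyclohexyl ring, a longer chain or an amine would behave at this carbon.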